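Trading 2-methylphenyl for 2,4-dichlorophenyl: what to expect

A few compounds are considered here, and "the series" means these few. Any claim that something is new, unique, unknown or untested is made for them only; others in the source may bear on it.

Measured so far:
Compound 1, `Cc1ccc(NC(=O)Nc2cccc(CNc3nccnc3Cl)c2)cc1`: 11900 nM
Compound 2, `Cc1ccc(NC(=O)Nc2cccc(CNc3nccnc3Cl)c2)cc1Cl`: 17500 nM
Compound 3, `Cc1ccccc1NC(=O)Nc1cccc(CNc2nccnc2Cl)c1`: 14000 nM

These three compounds share one core and differ only in the aryl group on an amide-type nitrogen. In a functional assay on MGC-803 cells (Homo sapiens) for antiproliferative activity, read by MTT assay, with a stated time of 48 h (on this read-out higher numbers stand for weaker inhibition and lower numbers for stronger inhibition), compound 3 gives 14000 nM, the second highest of the three numbers; its nearest neighbour is compound 1, and the three values sit within the scatter of one another, so no order among them can be claimed.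

Compound 4, `O=C(Nc1cccc(CNc2nccnc2Cl)c1)Nc1ccc(Cl)cc1Cl`, has not yet been measured. Its difference from compound 3 is 2,4-dichlorophenyl in place of 2-methylphenyl on an amide-type nitrogen.

Going by the values given here, two measured steps bear on this change. The step of a 1.5-fold higher number from compound 1 to compound 2 (0.17 log units; within the scatter) shows what adding a chloro to the aryl group did, and the step of a 1.2-fold higher number from compound 1 to compound 3 (0.07 log units; within the scatter) shows what moving the methyl did. Both stayed within the scatter. The change to compound 4 combines removing a methyl with adding two chloro groups, and nothing measured here points to a shift beyond the scatter in either direction.

Compound 4 is therefore expected to give about 15000 nM in this assay, a step of a 1.1-fold higher number from compound 3 to compound 4 (0.03 log units; within the scatter), with a range from 6000 nM to 40000 nM.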

Compound 4, half-maximal inhibitory concentration: 6430 nM
The estimate for compound 4 lay 2.3-fold (0.37 log units) above the measured number; the range from low to high includes it.
By their numbers in this assay, from the lowest: compounds 4, 1, 3 and 2 (each within the scatter of the next, the first and the last beyond it).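

In this assay, going by these compounds alone, no change of the aryl group on this amide-type nitrogen among the earlier compounds moved the number beyond the scatter, whereas 2,4-dichlorophenyl does so twice: it gives a 2.2-fold lower number from compound 3 to compound 4 (0.34 log units; beyond the scatter) in place of 2-methylphenyl and a 2.7-fold lower number from compound 2 to compound 4 (0.43 log units; beyond the scatter) in place of 3-chloro-4-methylphenyl, both modest steps. In place of 4-methylphenyl the same group gives a 1.9-fold lower number from compound 1 to compound 4 (0.27 log units; within the scatter) and stays within the scatter, so compound 4 cannot be separated from compound 1, and the position shows only a small response that depends on which group is being replaced. Nothing measured here explains why this group reads differently from the other aryl groups.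

The compounds shown carry only methyl and chloro on this aryl ring, so it remains open whether both chloro groups are needed for these steps or whether 2-chlorophenyl or 4-chlorophenyl alone would give the same reading. On these data alone, it is also open how an unsubstituted phenyl, or a ring bearing fluoro, methoxy or trifluoromethyl, would read on this nitrogen.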